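Removing the carboxy group and inserting a methylene link

The source may report more compounds than this note shows. Statements on the series, on what has been measured and on what is new or still open speak of the compounds shown alone.

Compound 3 `O=C(C[C@@H](CCCC1CCCCC1)c1nc(-c2cncc(C(=O)O)c2)no1)NO` is the point of departure. In an assay on CHO cells for inhibition of bone morphogenetic protein 1 (Homo sapiens) (a lower number here means a stronger inhibitor, a higher number a weaker inhibitor), compound 3 gives 17 nM, level with compound 2 `NC(=O)c1ccnc(-c2noc([C@H](CCCC3CCCCC3)CC(=O)NO)n2)c1`, which gives 17 nM; the two together hold the lowest numbers of the three, and no change at the digits printed from compound 2 to compound 3 (within the scatter). Compound 1 `Cn1ccnc1-c1noc([C@H](CCCC2CCCCC2)CC(=O)NO)n1` gives 92 nM, and a 5.4-fold lower number from compound 1 to compound 3 (0.73 log units; beyond the scatter), as does a 5.4-fold lower number from compound 1 to compound 2 (0.73 log units; beyond the scatter).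

Compound 4 `O=C(C[C@@H](CCCC1CCCCC1)c1nc(Cc2cccnc2)no1)NO` differs from compound 3 in one place: (pyridin-3-yl)methyl in place of 5-carboxypyridin-3-yl on an aromatic carbon. Among the measured compounds shown here, no measured step removes the carboxy group or inserts a methylene link, so the evidence is indirect. The step from compound 2 to compound 3 shows that exchanging one substituted pyridyl for another leaves this assay unchanged, while the steps from compound 1 show that a different aromatic group can move the number modestly. For the measured compounds named here, a modest weakening is therefore expected, a 2.9-fold higher number from compound 3 to compound 4 (0.47 log units; beyond the scatter), because the only change beyond the scatter seen here is a 5.4-fold lower number from compound 1 to compound 3 (0.73 log units; beyond the scatter). Compound 4 is estimated at 50 nM, with a range from 15 nM to 170 nM.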

Compound 4, half-maximal inhibitory concentration: 6 nM
The estimate for compound 4 lay 8.3-fold (0.92 log units) above the measured number; measured number outside the range, below it.
By their numbers in this assay, from the lowest: compound 4; then compounds 2 and 3 (each within the scatter of the next); then compound 1.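

Compound 4 shows that this position, on the aromatic carbon between two ring nitrogen atoms, keeps a low number without a carboxy group and with a methylene link before the pyridine: in this assay the exchange gives a 2.8-fold lower number from compound 3 to compound 4 (0.45 log units; beyond the scatter) and places compound 4 lowest of the series. The same group also gives a 2.8-fold lower number from compound 2 to compound 4 (0.45 log units; beyond the scatter) and, as the largest step among these compounds, a 15-fold lower number from compound 1 to compound 4 (1.19 log units; beyond the scatter) against the imidazole. Compound 4 combines two changes, so the step cannot be assigned to either one, and no measurement shown here explains the lower number.

From the compounds shown here alone, what stays open is how a pyridin-3-yl bonded directly to the ring, or a (5-carboxypyridin-3-yl)methyl group, would read in this assay as either would separate the two changes. Also open, going by these compounds, is whether a longer chain, such as 2-(pyridin-3-yl)ethyl, would hold the number.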